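The compounds below may be only part of what the source reports. "The series", "measured", "known", "first", "only" and "open" are said of these compounds alone.

Measured in a functional assay on HL-60 cells (Homo sapiens) for antiproliferative activity, read by MTT assay, with a stated time of 48 h; on this read-out higher numbers stand for weaker inhibition and lower numbers for stronger inhibition:
- compound 1 `CO[C@]1(C)/C=C/C(=O)/C(CO)=C\C[C@](C)(CCC=C(C)C)/C=C/[C@H]1OC(=O)C=C(C)C`: 14300 nM
- compound 2 `CC(C)=CCC[C@]1(C)/C=C/[C@@H](OC(=O)C=C(C)C)[C@](C)(O)/C=C/C(=O)/C(C(=O)O)=C\C1`: > 10000 nM

Compound 2 stands only at a limit of the assay, so > 10000 nM is not a number. The next analogue to be tested in this assay is compound 3 `CC(C)=CCC[C@]1(C)/C=C/[C@@H](OC(=O)C=C(C)C)[C@](C)(O)/C=C/C(=O)/C(C[Si](C)(C)C(C)(C)C)=C\C1`. On a double-bonded ring carbon, it carries a group of 8 heavy atoms (7 carbon, 1 silicon; no ring) in place of the carboxy of compound 2: a group of 8 heavy atoms (7 carbon, 1 silicon; no ring) in place of a group of 3 heavy atoms (1 carbon, 2 oxygen; no ring), on a double-bonded ring carbon. Among the compounds with values here, no measured step covers this change. Within the data shown here, the only firm number is that of compound 1, at 14300 nM, so weak inhibition remains the likely starting expectation. A moderate move towards stronger inhibition is expected, with a real chance of none; the expected step is an at least 1.6-fold lower number from compound 2 to compound 3 (0.22 log units; that floor lies within the scatter). For compound 3 the estimate is 6000 nM, with an expected range of 1500 nM to 25000 nM.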

Compound 3, half-maximal inhibitory concentration: 2770 nM
Compound 3: the middle estimate sits 2.2-fold (0.34 log units) above what was measured; measured number inside the range.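

In this assay, replacing the carboxy on the double-bonded ring carbon with a group of 8 heavy atoms (7 carbon, 1 silicon), which has 0 hydrogen-bond donors and 0 hydrogen-bond acceptors, gives an at least 3.6-fold lower number from compound 2 to compound 3 (0.55 log units; beyond the scatter). Within the data shown here, this is the first measured step at this position, and it shows that a carboxy is not needed here for the inhibition seen with compound 3. Compound 2 stands at a limit of the assay, not at a number, so the step gives only a floor and its full size stays unknown: the limit of > 10000 nM in this assay, at which 1 of the 3 values shown sits.

On these data alone, whether the silicon atom matters, or whether an all-carbon chain, a methyl ester or a primary amide on this carbon would give a similar number, remains open. Compound 1 differs from compound 2 and compound 3 in more than one place, so it says nothing about this carbon alone.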